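A few compounds are considered here, and "the series" means these few. Any claim that something is new, unique, unknown or untested is made for them only; others in the source may bear on it.

Compound 1 `O=C(Nc1ccc(F)cc1)N1N=C(c2ccc(Br)cc2)CC1c1ccc(F)cc1` gives > 10000 nM in an assay on HEK293 cells for inhibition of Voltage-dependent L-type calcium channel subunit alpha-1C (Homo sapiens), read by FLIPR and calcium flux, with a stated time of 3 min (on this read-out lower numbers stand for stronger inhibition and higher numbers for weaker inhibition), a limit of the assay.
Compound 2 `COCCOc1ccc(C2(CCO)CC(c3ccccc3)=NN2C(=O)Nc2ccc(F)cc2)cc1` gives 6300 nM in this assay.

Among the measured compounds shown here, compound 2 therefore holds the only number in this assay; the other entry is the limit of > 10000 nM in this assay, at which 1 of the 2 values shown sits. Compound 3 `CS(=O)(=O)c1ccc(C2(CCO)CC(c3ccccc3)=NN2C(=O)Nc2ccc(F)cc2)cc1` differs from compound 2 by methylsulfonyl in place of 2-methoxyethoxy on an aromatic carbon. No measured pair carries this change, so nothing shown sets its size or direction. With activity already weak in compound 2 at 6300 nM, compound 3 is expected to move only within the scatter, a step of a 1.1-fold higher number from compound 2 to compound 3 (0.05 log units; within the scatter). Compound 3 is thus estimated at 7000 nM, between 2500 nM and 20000 nM.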

Compound 3, half-maximal inhibitory concentration: > 10000 nM
Compound 3: no number, only a limit (the forecaster's own chance of this, stated with the estimate: 35%); middle value at least 1.4-fold (0.15 log units) from the limit.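

Placing methylsulfonyl in place of 2-methoxyethoxy on an aromatic carbon gives, in this assay, an at least 1.5-fold higher number from compound 2 to compound 3 (0.20 log units; that floor lies within the scatter), the first step that can be read at this position. So this change brought no stronger inhibition, though the step cannot establish a real loss. The entry for compound 3 is a limit of the assay and not a number, and compound 1 sits at the same limit: the limit of > 10000 nM in this assay, at which 2 of the 3 values shown sit.

Still open, as far as these compounds go, is how far compound 3 truly lies from compound 2. Also open, from the compounds shown here alone, is whether an amine, a carboxylic acid or a longer ether chain at this position would give a clearly lower number.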